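Aminomethyl to methyl on the benzyloxy arm of the series

This account rests on a few compounds, and the source may have more. Where it says the series, first, only, none or still open, it means among the compounds named here.

Working notes. The shared core of compound 1 `NCc1ccccc1COc1nc(N)nc2nc[nH]c12` carries a benzyloxy arm bearing an aminomethyl group. In an assay with Methylated-DNA--protein-cysteine methyltransferase (Homo sapiens) as the target, in the absence of a further agent (a higher number here means that more compound is needed for the effect, a lower number that less compound is needed), compound 1 gives 80 uM, the highest of the three numbers recorded so far. Compound 2 `Cc1ccc(COc2nc(N)nc3nc[nH]c23)cc1`, a methyl-bearing analogue, gives 0.32 uM in this assay; compound 3 `Cc1cccc(COc2nc(N)nc3nc[nH]c23)c1`, also methyl-bearing, gives 0.25 uM. Both sit far below compound 1, by margins well beyond the scatter, while compounds 2 and 3 lie within the scatter of each other.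

Compound 4 `Cc1ccccc1COc1nc(N)nc2nc[nH]c12` has not yet been measured. Its difference from compound 1 is hydrogen in place of amino on a saturated chain carbon bound to an aromatic carbon, so that the aminomethyl of compound 1 becomes a methyl. Among the measured compounds shown here, no measured pair in the set shows this exact step. Because compound 2 gives 0.32 uM and compound 3 gives 0.25 uM and both of these methyl-bearing analogues sit so far below compound 1, a large downward step from compound 1 to compound 4 is expected, estimated as a 160-fold lower number from compound 1 to compound 4 (2.20 log units; beyond the scatter). Compound 4 is therefore expected to give about 0.5 uM in this assay, within a range of 0.12 uM to 3 uM.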

Compound 4, concentration for half-maximal effect: 185 uM
Beside the measured number, compound 4's estimate is 370-fold (2.57 log units) below it; the whole stated range lies below it.
By their numbers in this assay, from the lowest: compounds 3 and 2 (each within the scatter of the next); then compound 1; then compound 4.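

In this assay, hydrogen in place of amino on a saturated chain carbon bound to an aromatic carbon gives a 2.3-fold higher number from compound 1 to compound 4 (0.36 log units; beyond the scatter), a modest step that runs upward, so the aminomethyl of compound 1 is not what keeps its number high. A methyl alone does not bring the low numbers of the other methyl-bearing analogues: compound 2 gives 0.32 uM and compound 3 gives 0.25 uM, whereas compound 4 gives 185 uM. No measurement at hand accounts for the step.

Open, on these data alone, is whether a hydroxymethyl, a carboxylic acid or a longer chain on this saturated carbon position would move the number in either direction. Also open, as far as these compounds go, is what a benzyloxy arm with no substituent at all would give in this assay.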